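The compounds below may be only part of what the source reports. "The series", "measured", "known", "first", "only" and "open" are said of these compounds alone.

Working notes on the series. In a functional assay on A549 cells (Homo sapiens) for antiproliferative activity, read by CCK-8 assay, with a stated time of 72 h (a higher number here means a weaker inhibitor of growth, a lower number a stronger inhibitor of growth), compound 1 (`CCC1C(=O)N(C)c2cnc(-n3ccc4cc(C(=O)NC)ccc43)nc2N1c1ccn(C)n1`) gives 43100 nM, and compound 2 (`CCC1C(=O)N(C)c2cnc(-n3ccc4cc(C(=O)NC5CCCC5)ccc43)nc2N1c1ccn(C)n1`) gives 39500 nM. Compound 2 holds the lower of the two numbers, but the gap to compound 1 is within the scatter, so the two stand level.

The next compound is compound 3 (`CCC1C(=O)N(C)c2cnc(-n3ccc4cc(C(N)=O)ccc43)nc2N1c1ccn(C)n1`), which differs from compound 2 as follows: hydrogen in place of cyclopentyl on an amide-type nitrogen. In words, this is hydrogen in place of cyclopentyl on an amide-type nitrogen.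

Among the compounds with values here, one measured step bears on this change, also on an amide-type nitrogen: cyclopentyl in place of methyl, which gave a 1.1-fold lower number from compound 1 to compound 2 (0.04 log units; within the scatter). That step is small, so no change beyond the scatter is expected in this assay, and no direction is favoured. Within the data shown here, no measured compound carries hydrogen at this nitrogen, however, so the range is kept wide.

The step expected is a 1.3-fold lower number from compound 2 to compound 3 (0.12 log units; within the scatter). For compound 3 the estimated value is 30000 nM, with an expected range from 10000 nM to 80000 nM.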

Compound 3, concentration for 50% growth inhibition: 39500 nM
Compound 3: middle estimate off by 1.3-fold (0.12 log units), on the low side; the range from low to high includes it.
By their numbers in this assay, from the lowest: compounds 2, 3 and 1 (each within the scatter of the next).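

In this assay, the hydrogen case now joins the methyl and cyclopentyl cases on this amide-type nitrogen: hydrogen in place of cyclopentyl gives no change at the digits printed from compound 2 to compound 3 (within the scatter), and hydrogen in place of methyl gives a 1.1-fold lower number from compound 1 to compound 3 (0.04 log units; within the scatter). With compound 3 at 39500 nM, all three compounds stand level, so going from a hydrogen atom with no heavy atom to a cyclopentyl group of 5 heavy atoms leaves the number within the scatter. Across compound 1, compound 2 and compound 3, this nitrogen therefore shows no dependence on its substituent, and no information is available to explain this flat result.

The compounds shown leave open whether any substituent on this nitrogen can move the number beyond the scatter, for example a longer chain ending in an amine, a chain ending in a carboxylic acid, or a phenyl ring. They also leave open whether changes elsewhere on the shared core would shift a number that stays level across all three amides.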